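The source may report more compounds than this note shows. Statements on the series, on what has been measured and on what is new or still open speak of the compounds shown alone.

In an ADME assay on a cell-free system (plasma, Homo sapiens) for protein binding (a higher number here means a larger unbound share of the compound, a lower number a smaller unbound share), two compounds have been measured so far:

Compound 1 `O=c1n(Cc2cc3cnccc3n2CCCC(F)(F)F)c2cnccc2n1C1CC1`: 0.472
Compound 2 `COc1ccc(-n2c(=O)n(Cc3cc4cc(Cl)ccc4n3CCCC#N)c3cnccc32)cc1OC`: 0.008

Compound 2 holds the lower of these two numbers, and its gap to compound 1 lies beyond the scatter. Compound 3 `N#CCCCn1c(Cn2c(=O)n(C3CC3)c3ccncc32)cc2cc(Cl)ccc21` has cyclopropyl in place of 3,4-dimethoxyphenyl on an aromatic nitrogen. Among the measured compounds shown here, compound 1 also carries cyclopropyl there, but it differs from compound 3 elsewhere, and no measured step isolates this change. The expected change is a 6.3-fold higher number from compound 2 to compound 3 (0.80 log units; beyond the scatter), upward and beyond the scatter. For compound 3 the estimated value is 0.05, with an expected range of 0.02 to 0.12.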

Compound 3, unbound fraction: 0.036
Beside the measured number, compound 3's estimate is 1.4-fold (0.14 log units) above it; low and high end bracket the measured number.
By their numbers in this assay, from the lowest: compound 2; then compound 3; then compound 1.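

In this assay, among the compounds shown here, putting cyclopropyl in place of 3,4-dimethoxyphenyl on an aromatic nitrogen gives a 4.5-fold higher number from compound 2 to compound 3 (0.65 log units; beyond the scatter) and is the first single change that can be read in this set. It shows that the group on this nitrogen alone can shift the unbound share beyond the scatter, though only modestly, with the rest of the structure held fixed. Nothing measured here accounts for the rise.

From the compounds shown here alone, whether a methyl group or a piperidine ring on this nitrogen would shift the number further remains open. So does the separate contribution of the 4,4,4-trifluorobutyl and nitrile-bearing chains.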